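A few compounds are considered here, and "the series" means these few. Any claim that something is new, unique, unknown or untested is made for them only; others in the source may bear on it.

Compound 1 `Cc1ccc(S(=O)(=O)Oc2ccccc2/C=C(\C#N)C(=O)Nc2nnc(Cc3cccc4ccccc34)s2)cc1`: 23%
Compound 2 `N#C/C(=C\c1ccccc1OS(=O)(=O)c1ccc(F)cc1)C(=O)Nc1nnc(Cc2cccc3ccccc23)s1`: 15%

Among the compounds with values here, in an ADME assay on HEK-293T cells (Homo sapiens) for inhibition, read by CCK-8 assay, with a stated time of 48 h, tested at 20 uM (on this read-out higher numbers stand for more inhibition of growth at the one concentration tested and lower numbers for less inhibition of growth), compound 1 gives 23%, and its only neighbour on these numbers is reached by a number 8 percentage points lower from compound 1 to compound 2 (within the scatter). That step, fluoro in place of methyl on an aromatic carbon, is the only one measured, and it involves a different group, so it bears only loosely on what follows. Compound 3 `Cc1ccc(S(=O)(=O)Oc2ccccc2/C=C(\C#N)C(=O)Nc2nnc(Cc3cccc(F)c3)s2)cc1` carries a larger change: 3-fluorophenyl in place of naphthalen-1-yl on a saturated chain carbon bound to an aromatic carbon. Within the data shown here, no measured compound tests this swap, so little movement is assumed. The expected step is a number 5 percentage points lower from compound 1 to compound 3 (within the scatter), with wide uncertainty. Compound 3 is estimated at 18%, within a range of 4% to 36%.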

Compound 3, percent growth inhibition at one concentration: 9%
For compound 3 the middle estimate is 9 percentage points above the measured one; the measured number falls inside the stated range.
By their numbers in this assay, from the lowest: compounds 3, 2 and 1 (each within the scatter of the next, the first and the last beyond it).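

In this assay, within the data shown here, the group on the saturated chain carbon shifts the result: 3-fluorophenyl in place of naphthalen-1-yl gives a number 14 percentage points lower from compound 1 to compound 3 (beyond the scatter) while the only earlier step, fluoro in place of methyl, stayed within the scatter. This swap removes one aromatic ring and adds a fluorine at once, so the numbers cannot separate the two changes. Nothing measured here speaks to why the number falls.

Still open, going by these compounds, is where an unsubstituted phenyl, a naphthalen-2-yl or a cyclohexyl group would fall at this position, and whether any of them would separate the loss of the ring from the added fluorine.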